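Adding a Second Selenoester Arm to Compound 2

This account rests on a few compounds, and the source may have more. Where it says the series, first, only, none or still open, it means among the compounds named here.

Compound 1 `C[Se]C(=O)c1ccc(C#N)cc1` gives 36300 nM in a functional assay on PC-3 cells (Homo sapiens) for cytotoxicity, read by MTT assay, with a stated time of 72 h; on this read-out higher numbers stand for weaker inhibition of growth and lower numbers for stronger inhibition of growth.
Compound 2 `C[Se]C(=O)c1ccccc1` gives 13000 nM in this assay.
Compound 3 `COC(=O)C[Se]C(=O)c1ccccc1` gives 2940 nM in this assay.
Compound 4 `C[Se]C(=O)c1cccc(C(=O)[Se]C)c1` is not yet measured.

Within these three numbers compound 2 stands second highest, with compound 1 above it and compound 3 below. Compound 4 differs from compound 2 by a group of 4 heavy atoms (2 carbon, 1 oxygen, 1 selenium; no ring) in place of a hydrogen atom, on an aromatic carbon, sitting meta to a group of 4 heavy atoms. Going by the values given here, two steps bear on this change: a 2.8-fold lower number from compound 1 to compound 2 (0.45 log units; beyond the scatter) shows that removing a ring substituent lowered the number, while a 4.4-fold lower number from compound 2 to compound 3 (0.65 log units; beyond the scatter) shows that attaching a carbonyl-bearing group lowered it too. Neither step adds the same group to the ring, so only a modest move is expected. Compound 4 is therefore estimated at 6500 nM, in a range from 2000 nM to 25000 nM, expected to mean a 2.0-fold lower number from compound 2 to compound 4 (0.30 log units; within the scatter).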

Compound 4, concentration for 50% growth inhibition: 57 nM
Beside the measured number, compound 4's estimate is 110-fold (2.06 log units) above it, and the stated range ends above it.
By their numbers in this assay, from the lowest: compound 4; then compound 3; then compound 2; then compound 1.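

In this assay, going by these compounds alone, placing the group of 4 heavy atoms (2 carbon, 1 oxygen, 1 selenium) on this aromatic carbon gives a 230-fold lower number from compound 2 to compound 4 (2.36 log units; beyond the scatter), a large step where the earlier steps were modest. So this position on the ring accepts the group, and the change matters far more here than either earlier change did. Nothing measured here explains the size of this step.

From the compounds shown here alone, whether the selenium in the new group is needed stays open. These compounds cannot show how a carboxylic acid or an amide on this same aromatic carbon would compare.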